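A few compounds are considered here, and "the series" means these few. Any claim that something is new, unique, unknown or untested is made for them only; others in the source may bear on it.

Measured compounds:
compound 1 `Nc1nc(NCc2ccccc2)nc(-c2ccccc2CO)n1`: 4.35
compound 2 `Nc1nc(NCc2ccccc2)nc(-c2c(F)cccc2CO)n1`: 3.69

Going by the values given here, in a functional assay on cells for positive allosteric modulation of G-protein coupled receptor 68 (Homo sapiens), read by a luciferase reporter and cAMP accumulation, with a stated time of 30 min, at pH 6.8 and pH 8.3, in the presence of a further agent that is not named here (on this read-out lower numbers stand for lower potency and higher numbers for higher potency (the scale is a negative logarithm)), compound 2 gives 3.69, the lower of the two numbers so far; compound 1 gives 4.35. Among the compounds with values here, the only measured step is a number 0.66 log units lower from compound 1 to compound 2 (beyond the scatter). Compound 3 `Nc1nc(NCc2ccc(F)cc2)nc(-c2c(F)cccc2CO)n1` differs from compound 2 by fluoro in place of hydrogen on an aromatic carbon. Within the data shown here, no measured step covers a fluoro at this place; the one known step concerns a fluoro placed elsewhere and bears only loosely here. From compound 2 to compound 3 a step of a number 0.09 log units lower from compound 2 to compound 3 (within the scatter) is expected, not beyond the scatter. The estimate for compound 3 in this assay is 3.6, range 3 to 4.2.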

Compound 3, negative logarithm of the antagonist equilibrium constant: 4.45
The estimate for compound 3 lay 0.85 log units below the measured number, and the stated range ends below it.
By their numbers in this assay, from the lowest: compound 2; then compounds 1 and 3 (each within the scatter of the next).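

Fluoro in place of hydrogen, para to a large group on the benzyl, gives a number 0.76 log units higher from compound 2 to compound 3 (beyond the scatter) in this assay. The same exchange on the other aromatic ring gave a number 0.66 log units lower from compound 1 to compound 2 (beyond the scatter), so across these two steps its direction depends on the ring that carries it. Nothing available explains this reversal.

As far as these compounds go, whether the 4-fluorobenzyl step would hold without the fluoro on the other ring remains open. Also open, from the compounds shown here alone, is how chloro, methoxy or an amine would compare with fluoro at this place.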